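This account rests on a few compounds, and the source may have more. Where it says the series, first, only, none or still open, it means among the compounds named here.

Going by the values given here, compound 1, `Cc1ccc(S(=O)(=O)NCc2cn(C[C@H](O)[C@H]3OC(=O)C(OCc4ccccc4)=C3OCc3ccccc3)nn2)cc1`, is the only compound of this pair with a measured number: in a functional assay on CFPAC-1 cells (Homo sapiens) for antiproliferative activity, read by MTT assay, with a stated time of 72 h (on this read-out lower numbers stand for stronger inhibition and higher numbers for weaker inhibition), compound 1 gives 68000 nM. Compound 2, `Cc1ccc(-c2cn(C/C=C3\OC(=O)C(OCc4ccccc4)=C3OCc3ccccc3)nn2)cc1`, is the other compound tested in this assay; compound 2 reaches only > 100000 nM, which is a limit of the assay and not a number, in line with the limit of > 100000 nM in this assay, at which 1 of the 2 values shown sits. Compound 3, `Cc1ccc(-c2cn(C[C@H](O)[C@H]3OC(=O)C(OCc4ccccc4)=C3OCc3ccccc3)nn2)cc1`, is not yet measured. Compound 3 differs from compound 1 in one place: 4-methylphenyl in place of (((4-methylphenyl)sulfonyl)amino)methyl on an aromatic carbon. Among the compounds with values here, no step between two measured compounds shows how much this change alone moves this assay. Compound 2 carries the same 4-methylphenyl on its five-membered ring, yet its double bond outside aromatic rings in place of the hydroxyl-bearing linker of compound 1 and compound 3 keeps the comparison indirect. The expectation for compound 3 is a step of a 1.2-fold higher number from compound 1 to compound 3 (0.07 log units; within the scatter), modest and within or near the scatter. Compound 3 is estimated at 80000 nM, in the range 30000 nM to 150000 nM.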

Compound 3, half-maximal inhibitory concentration: > 100000 nM
Compound 3: no number, only a limit; the forecaster's own chance of this, stated with the estimate: 35%; at least 1.2-fold (0.09 log units) between middle value and limit.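

On the aromatic carbon of the five-membered ring with 3 nitrogen, 4-methylphenyl in place of (((4-methylphenyl)sulfonyl)amino)methyl gives an at least 1.4-fold higher number from compound 1 to compound 3 (0.16 log units; that floor lies within the scatter) in this assay, the first step read at this position. On these data alone, this step has a floor but no ceiling, so the change shows no gain in inhibition of these cells, while its true cost remains unknown. Compound 1 therefore remains the only compound with a number, and the upper end of the assay now bounds most of the set: the limit of > 100000 nM in this assay, at which 2 of the 3 values shown sit.

As far as these compounds go, it remains open which part of the larger group goes with the measurable value of compound 1: the sulfonyl, the amino hydrogen or the methylene link. An aminomethyl group or a benzyl group on the same carbon would help to separate these parts.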